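Swapping Fluoro for Chloro on an Antiproliferative Amide

A few compounds are considered here, and "the series" means these few. Any claim that something is new, unique, unknown or untested is made for them only; others in the source may bear on it.

compound 1 `CN(C)CCCOc1ccc(NC(=O)c2cccc(-c3cccc(O)c3)c2)cc1`: 7850 nM
compound 2 `CN(C)CCCOc1ccc(NC(=O)c2cccc(-c3cccc(O)c3)c2)cc1F`: 1940 nM

In a functional assay on MCF7 cells (Homo sapiens) for antiproliferative activity, read by MTT assay, with a stated time of 48 h (a higher number here means a weaker inhibitor, a lower number a stronger inhibitor), compound 2 gives 1940 nM, the lowest of the two numbers; compound 1 gives 7850 nM. Compound 3 `CN(C)CCCOc1ccc(NC(=O)c2cccc(-c3cccc(O)c3)c2)cc1Cl` differs from compound 2 by chloro in place of fluoro on an aromatic carbon. Within the data shown here, the only step that bears on this is a 4.0-fold lower number from compound 1 to compound 2 (0.61 log units; beyond the scatter), where placing fluoro on that carbon changed the number. Among the measured compounds shown here, no measured pair compares fluoro with chloro, so a step in this assay of about the scatter, slightly toward lower numbers, is expected: compound 3 is estimated at 1500 nM (range 500 nM to 5000 nM), an expected change of a 1.3-fold lower number from compound 2 to compound 3 (0.11 log units; within the scatter).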

Compound 3, half-maximal inhibitory concentration: 47100 nM
The estimate for compound 3 lay 31-fold (1.50 log units) below the measured number; the whole stated range lies below it.
By their numbers in this assay, from the lowest: compound 2; then compound 1; then compound 3.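

In this assay the choice of halogen on this carbon, ortho to a 3-(dimethylamino)propoxy group, matters greatly, with chloro in place of fluoro giving a 24-fold higher number from compound 2 to compound 3 (1.39 log units; beyond the scatter) at this position. Measured against hydrogen, the two halogens move the number in opposite directions: chloro gives a 6.0-fold higher number from compound 1 to compound 3 (0.78 log units; beyond the scatter) on this carbon, while fluoro gives a 4.0-fold lower number from compound 1 to compound 2 (0.61 log units; beyond the scatter) on the same carbon. Nothing measured here explains this split.

From the compounds shown here alone, whether bromo, methyl or methoxy on this carbon would side with fluoro or with chloro stays open. So does whether the same swap would behave alike with a shorter chain in place of the 3-(dimethylamino)propoxy group.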